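A few compounds are considered here, and "the series" means these few. Any claim that something is new, unique, unknown or untested is made for them only; others in the source may bear on it.

Of the compounds shown here, three of a shared core have been measured in a functional assay on NCI-H460 cells (Homo sapiens) for antiproliferative activity, read by CCK-8 assay, with a stated time of 72 h, tested at 2 uM; on this read-out higher numbers stand for a stronger effect at the one concentration tested and lower numbers for a weaker effect. Compound 1 `Nc1ccccc1NC(=O)c1ccc(Cn2cnc3c(NCc4ccccc4)nc(Cl)nc32)cc1` gives 44.7% in this assay, compound 2 `Nc1ccccc1NC(=O)c1ccc(Cn2cnc3c(Nc4cccc(OC(F)(F)F)c4)nc(Cl)nc32)cc1` gives 47.7%, and compound 3 `CC1CCN(c2nc(Cl)nc3c2ncn3Cc2ccc(C(=O)Nc3ccccc3N)cc2)CC1` gives 11.8%. Compound 3 stands lowest of the three: the step of a number 32.9 percentage points lower from compound 1 to compound 3 (beyond the scatter) and the step of a number 35.9 percentage points lower from compound 2 to compound 3 (beyond the scatter) both fall beyond the scatter, while the step of a number 3 percentage points higher from compound 1 to compound 2 (within the scatter) stays within it.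

Compound 4 `Nc1ccccc1NC(=O)c1ccc(Cn2cnc3c(Nc4cccc(Cl)c4)nc(Cl)nc32)cc1` is the next structure. It differs from compound 3 by (3-chlorophenyl)amino in place of 4-methylpiperidin-1-yl on an aromatic carbon.

For the measured compounds named here, two measured steps bear on this change. The step of a number 32.9 percentage points lower from compound 1 to compound 3 (beyond the scatter) and the step of a number 35.9 percentage points lower from compound 2 to compound 3 (beyond the scatter) both show that putting 4-methylpiperidin-1-yl in place of a nitrogen-linked group on that carbon costs a large amount in this assay. Compound 4 reverses that move, and its (3-chlorophenyl)amino group resembles the (3-(trifluoromethoxy)phenyl)amino group of compound 2. A large rise is therefore expected, estimated as a number 34.2 percentage points higher from compound 3 to compound 4 (beyond the scatter). Compound 4 is expected to give about 46% in this assay, within a range from 34% to 58%.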

Compound 4, a percentage reported as inhibition, at one concentration (the size of the read-out at that concentration, not a potency): 10.3%
For compound 4 the middle estimate is 35.7 percentage points above the measured one; the measured number lies below the stated range.
By their numbers in this assay, from the lowest: compounds 4 and 3 (each within the scatter of the next); then compounds 1 and 2 (each within the scatter of the next).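

In this assay, a nitrogen-linked aromatic ring at this carbon of the shared core does not by itself preserve the effect: the step to (3-chlorophenyl)amino from 4-methylpiperidin-1-yl is a number 1.5 percentage points lower from compound 3 to compound 4 (within the scatter). The substituent on that ring matters, since chloro in place of trifluoromethoxy gives a number 37.4 percentage points lower from compound 2 to compound 4 (beyond the scatter). The group on the nitrogen matters as well, since 3-chlorophenyl in place of benzyl gives a number 34.4 percentage points lower from compound 1 to compound 4 (beyond the scatter), so a link through nitrogen alone does not account for the higher values of compound 1 and compound 2.

No measured evidence here explains why chloro and trifluoromethoxy part so sharply on this ring. From the compounds shown here alone, it remains open whether a methoxy group or a fluoro group on the same ring would follow chloro or trifluoromethoxy.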